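Working notes: the step from compound 2 to compound 3

The compounds below may be only part of what the source reports. "The series", "measured", "known", "first", "only" and "open" are said of these compounds alone.

Compound 2 `COc1cc(-c2nnc3n2NC(c2ccco2)C(C(=O)c2ccc(-c4ccccc4)cc2)S3)cc(OC)c1OC` has been measured in a functional assay on MCF7 cells (Homo sapiens) for cytotoxicity, read by MTT assay, with a stated time of 48 h; on this read-out lower numbers stand for stronger inhibition and higher numbers for weaker inhibition. In this read-out compound 2 gives > 100000 nM, which is a limit of the assay and not a number. Compound 1 `COc1cc(-c2nnc3n2NC(c2ccco2)C(C(=O)c2ccc(C)cc2)S3)cc(OC)c1OC` gives > 100000 nM, again a limit rather than a number. The step that the two limits leave unreadable from compound 1 to compound 2 cannot be sized, because of the limit of > 100000 nM in this assay, at which 2 of the 2 values shown sit. Compound 3 `COc1cc(-c2nnc3n2NC(c2ccco2)C(C(=O)c2ccc(O)cc2)S3)cc(OC)c1OC` differs from compound 2 by hydroxy in place of phenyl on an aromatic carbon. Among the compounds with values here, no measured step bears on this change, and the only recorded step is itself unreadable, so the expectation for compound 3 rests on the standing of compound 2 alone. The step of a number no higher from compound 2 to compound 3 (the limit leaves the size open) is expected to be unreadable as well, with the result most likely remaining at the limit. Compound 3 is estimated at 100000 nM, with a range from 20000 nM to 300000 nM.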

Compound 3, half-maximal inhibitory concentration: 88900 nM
Estimate against measurement, compound 3: 1.1-fold (0.05 log units) above; the range from low to high includes it.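

In this assay, within the data shown here, compound 3 is the first compound to give a number rather than a limit, so the 4-hydroxyphenyl group brings the read-out within measurable range, though only just. Hydroxy in place of phenyl gives an at least 1.1-fold lower number from compound 2 to compound 3 (0.05 log units; that floor lies within the scatter), and hydroxy in place of methyl gives an at least 1.1-fold lower number from compound 1 to compound 3 (0.05 log units; that floor lies within the scatter). Each of these is only a floor, and it lies within the scatter, so no real difference from phenyl or methyl is shown, and the full size of both steps stays unknown because compound 1 and compound 2 each sit at a limit: the limit of > 100000 nM in this assay, at which 2 of the 3 values shown sit.

As far as these compounds go, whether an amine or a carboxylic acid at this position would lower the number further remains open. Among these compounds, with only one number, no order of groups at this position can yet be drawn.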